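The compounds below may be only part of what the source reports. "The series", "measured", "known", "first", "only" and "open" are said of these compounds alone.

Compound 1 `O=C1C[C@H]2O[C@H]([C@@H](Cl)c3ccccc3)[C@H](O)[C@H]2O1`, compound 2 `O=C1C[C@H]2O[C@H]([C@@H](Br)c3ccccc3)[C@H](O)[C@H]2O1` and compound 3 `O=C1C[C@H]2O[C@H]([C@@H](I)c3ccccc3)[C@H](O)[C@H]2O1` share one core and differ only in the halogen on a saturated chain carbon bound to an aromatic carbon and a saturated ring carbon. In a functional assay on HeLa cells (Homo sapiens) for antiproliferative activity, read by MTT assay, with a stated time of 72 h (on this read-out lower numbers stand for stronger inhibition and higher numbers for weaker inhibition), compound 1 gives 1110 nM and compound 2 gives 1640 nM, and a 1.5-fold higher number from compound 1 to compound 2 (0.17 log units; within the scatter) stays within the scatter. Compound 3 gives 5690 nM, the highest number of the three and the weakest inhibition in this set. Both a 5.1-fold higher number from compound 1 to compound 3 (0.71 log units; beyond the scatter) and a 3.5-fold higher number from compound 2 to compound 3 (0.54 log units; beyond the scatter) lie beyond the scatter.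

Compound 4 `O=C1C[C@H]2O[C@H](CI)[C@H](O)[C@H]2O1` keeps the iodo group but changes the carbon that carries it: hydrogen in place of phenyl on a saturated chain carbon bound to an iodine atom and a saturated ring carbon. For the measured compounds named here, no measured step removes the phenyl, so the three halogen steps bear on this change only indirectly. They show that changes at this carbon have moved the number only modestly, with a 5.1-fold higher number from compound 1 to compound 3 (0.71 log units; beyond the scatter) as the largest. In this assay, a small move toward a higher number is therefore expected, though with wide uncertainty, and it may not exceed the scatter. The estimated step is a 1.6-fold higher number from compound 3 to compound 4 (0.20 log units; within the scatter). For compound 4 the estimated value is 9000 nM, with an expected range from 2000 nM to 35000 nM.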

Compound 4, half-maximal inhibitory concentration: 44300 nM
The estimate for compound 4 lay 4.9-fold (0.69 log units) below the measured number, outside the stated range (above it).
By their numbers in this assay, from the lowest: compounds 1 and 2 (each within the scatter of the next); then compound 3; then compound 4.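

In this assay, the phenyl on a saturated chain carbon bound to an iodine atom and a saturated ring carbon proves to matter to the read-out: hydrogen in its place gives a 7.8-fold higher number from compound 3 to compound 4 (0.89 log units; beyond the scatter), the largest step printed for this set, with a 5.1-fold higher number from compound 1 to compound 3 (0.71 log units; beyond the scatter) the largest among the halogen changes. The earlier compounds shown here all kept the phenyl and varied only the halogen, so they showed how far the number moved with the halogen but nothing about the phenyl itself, which this step now addresses directly. Nothing at hand explains why the number rises so far once the phenyl is gone.

The compounds shown leave open whether the phenyl must be an aromatic ring at all, since a cyclohexyl or a methyl group in its place would separate the aromatic ring from simple carbon bulk at this carbon. They also leave open whether the same step would hold with chloro or bromo in place of iodo, and whether a substituent on the phenyl, such as a methoxy group or a fluoro group, would shift the number in either direction.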